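A few compounds are considered here, and "the series" means these few. Any claim that something is new, unique, unknown or untested is made for them only; others in the source may bear on it.

Measured so far:
- Compound 1 `CCNC(=O)c1nc(-c2ccc(CN(C)C)cc2)cnc1N`: in a physicochemical assay for solubility, at pH 6.8 (on this read-out higher numbers stand for higher solubility and lower numbers for lower solubility), compound 1 gives > 1000000 nM, which is a limit of the assay rather than a number.
- Compound 2 `CN(C)Cc1ccc(-c2cnc(N)c(C(=O)NC[C@@](C)(O)C(F)(F)F)n2)cc1`: in this assay compound 2 gives 510000 nM.
- Compound 3 `CN(C)Cc1ccc(-c2cnc(N)c(C(=O)NC3CCC(O)CC3)n2)cc1`: in this assay compound 3 gives 850000 nM.

Compound 2 holds the lowest of the two numbers; its nearest neighbour is compound 3, with a 1.7-fold higher number from compound 2 to compound 3 (0.22 log units; within the scatter). Compound 1 sits at the limit of > 1000000 nM in this assay, at which 1 of the 3 values shown sits.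

Compound 4 `C[C@@](O)(CNC(=O)c1nc(-c2ccc(CN3CCCC3)cc2)cnc1N)C(F)(F)F` differs from compound 2 in one place: pyrrolidin-1-yl in place of dimethylamino on a saturated chain carbon bound to an aromatic carbon. Going by the values given here, none of the measured steps touches this part of the molecule. The steps of an at least 1.9-fold lower number from compound 1 to compound 2 (0.29 log units; that floor lies within the scatter), an at least 1.1-fold lower number from compound 1 to compound 3 (0.07 log units; that floor lies within the scatter) and a 1.7-fold higher number from compound 2 to compound 3 (0.22 log units; within the scatter) all alter the group on the amide-type nitrogen and all stay within the scatter, so they give no direction for a change at the saturated chain carbon bound to the aromatic carbon. With nothing to support a shift beyond the scatter, compound 4 is expected near compound 2, and the step is estimated at a 1.3-fold lower number from compound 2 to compound 4 (0.11 log units; within the scatter). The estimate for compound 4 in this assay is 400000 nM, with a range from 180000 nM to 900000 nM.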

Compound 4, solubility: > 1000000 nM
Compound 4 was reported as a limit; the forecaster's own chance of this, stated with the estimate: 10%; middle value at least 2.5-fold (0.39 log units) away from the limit.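

The first change shown at the saturated chain carbon bound to an aromatic carbon, pyrrolidin-1-yl in place of dimethylamino, gives an at least 1.9-fold higher number from compound 2 to compound 4 (0.29 log units; that floor lies within the scatter). In this assay compound 4 gives > 1000000 nM, which is a limit of the assay and not a number. The swap therefore shows no drop on this read-out, but the size of the step stays unknown, and the top of the range no longer separates compounds in this series: the limit of > 1000000 nM in this assay, at which 2 of the 4 values shown sit.

From the compounds shown here alone, whether the true step from dimethylamino to pyrrolidin-1-yl lies beyond the scatter stays open. Also open, going by these compounds, is how other groups at this place would read, such as a morpholine, a piperidine or a carboxylic acid, particularly on a compound that does not sit at the limit.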